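Stilbene-type acids: methyl for methoxy on compound 1

The source may report more compounds than this note shows. Statements on the series, on what has been measured and on what is new or still open speak of the compounds shown alone.

Working notes on a small set tested in an ADME assay on HepG2 cells (Homo sapiens) for cytotoxicity, read by resazurin assay, with a stated time of 24 h; on this read-out lower numbers stand for higher toxicity in this test and higher numbers for lower toxicity in this test. Compound 1 `COc1cc(C=Cc2ccc3ccccc3c2)c(C(=O)O)c(OC)c1` is the reference point of this set. In this assay compound 1 gives only a limit of the assay, > 100000 nM, and not a measured number. Compound 2 `Oc1cc(CCc2ccc3ccccc3c2)cc(O)c1O` has also been tested. In this assay compound 2 likewise gives only a limit, > 100000 nM. Within the data shown here, both values shown therefore sit at the limit of > 100000 nM in this assay, at which 2 of the 2 values shown sit, so nothing in the set yet separates one compound from another, and no step between measured compounds can be drawn.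

The untested member is compound 3 `COc1cc(C)cc(C=Cc2ccc3ccccc3c2)c1C(=O)O`. It differs from compound 1 in one place: methyl in place of methoxy on an aromatic carbon. This is a small exchange that keeps the shared core of compound 1 and its carboxy group intact.

With both measured values resting at the same limit, no direction for the change can be taken from the set; the expectation is for no step beyond the scatter, a step that the limit leaves unreadable from compound 1 to compound 3, and compound 3 is expected to return a limit again. For compound 3 the estimate in this assay is 120000 nM, with a range from 40000 nM to 400000 nM.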

Compound 3, half-maximal cytotoxic concentration: 117000 nM
For compound 3 the middle estimate is 1.0-fold (0.01 log units) above the measured one, within the range that was stated.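

No new step can be read: compound 1 stands at a limit of the assay and not at a number, so its comparison with compound 3 has no readable size: the limit of > 100000 nM in this assay, at which 2 of the 3 values shown sit.

The compounds shown leave open whether methyl in place of methoxy on an aromatic carbon shifts the read-out in this assay at all.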